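Chloro in place of methoxy on the shared core

The source may hold more compounds than are shown below. What is called first, only, known or untested is meant among the compounds shown, and "the series" means these compounds.

In a physicochemical assay for solubility, read by HPLC, at pH 7.4 (a lower number here means a less soluble compound, a higher number a more soluble compound), compound 1 `Cc1[nH]c2ccccc2c(=O)c1Cc1ccccc1` gives 10000 nM. Compound 2 `Cc1[nH]c2ccc(Cl)cc2c(=O)c1Cc1ccccc1` reads < 2000 nM, which is a limit and not a number. Compound 3 `COc1cccc2[nH]c(C)c(Cc3ccccc3)c(=O)c12` reads > 20000 nM, also a limit, so no exact number is known for it. Compound 4 `Cc1[nH]c2cccc(Cl)c2c(=O)c1Cc1ccccc1` differs from compound 3 by chloro in place of methoxy on an aromatic carbon. Among the measured compounds shown here, two measured steps bear on this change. The chloro step shows an at least 5.0-fold lower number from compound 1 to compound 2 (0.69 log units; beyond the scatter), beyond the scatter, though that chloro sits elsewhere on the core. The methoxy step shows an at least 2.0-fold higher number from compound 1 to compound 3 (0.30 log units; that floor lies within the scatter), with a floor within the scatter. A clear fall beyond the scatter is therefore expected, and the expected step is an at least 8.0-fold lower number from compound 3 to compound 4 (0.90 log units; beyond the scatter). Compound 4 is estimated at 2500 nM, with an expected range of 1000 nM to 8000 nM.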

Compound 4, solubility: 2000 nM
Compound 4: the middle estimate sits 1.3-fold (0.10 log units) above what was measured; the range from low to high includes it.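

In this assay, among the compounds shown here, chloro on this aromatic carbon gives the first chloro step that has an exact size: a 5.0-fold lower number from compound 1 to compound 4 (0.70 log units; beyond the scatter). Set against methoxy on the same carbon, the change gives an at least 10-fold lower number from compound 3 to compound 4 (1.00 log units; beyond the scatter), and this size is only a floor. Compound 3 reads > 20000 nM, which is a limit and not a number.

As far as these compounds go, compound 2, with chloro elsewhere on the shared core, reads < 2000 nM, also a limit, so whether the two chloro placements differ stays open. From the compounds shown here alone, how an amine or a carboxylic acid on this carbon would read also remains open.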